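Amino in Place of Nitro: An Expected Antiproliferative Step

This account rests on a few compounds, and the source may have more. Where it says the series, first, only, none or still open, it means among the compounds named here.

Among the compounds with values here, in a functional assay on MDA-MB-231 cells (Homo sapiens) for antiproliferative activity, read by MTT assay, with a stated time of 72 h (a lower number here means a stronger inhibitor, a higher number a weaker inhibitor), three compounds have numbers so far. Compound 1 (`COc1cc(-c2nccn2-c2ccc3sccc3c2)cc(OC)c1OC`) gives 16800 nM as the highest number of the three. Compound 3 (`COc1ccc(C(=O)Nc2cc(OC)c(OC)c(OC)c2)cc1[N+](=O)[O-]`) gives 5700 nM and stands second highest, with a gap beyond the scatter on either side. Compound 2 (`COc1ccc(-n2ccnc2-c2cc(OC)c(OC)c(OC)c2)cc1N`) gives 1040 nM as the lowest number.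

Compound 4 (`COc1ccc(C(=O)Nc2cc(OC)c(OC)c(OC)c2)cc1N`) has not yet been measured. It differs from compound 3 in one place, on an aromatic carbon ortho to a methoxy group and meta to a large group, where amino stands in place of nitro (amino in place of nitro on an aromatic carbon). Within the data shown here, no measured pair isolates this change, so there is no direct step to lean on. The only indirect hint is that compound 2 also carries an amino group and gives 1040 nM on a different core. That is weak ground, so a modest shift toward a lower number in this assay is expected rather than a large one. The step expected is a 2.3-fold lower number from compound 3 to compound 4 (0.36 log units; beyond the scatter) and it would lie only a little beyond the scatter. For compound 4 the estimated value is 2500 nM with 700 nM to 9000 nM as the expected range.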

Compound 4, half-maximal inhibitory concentration: 94200 nM
Compound 4: middle estimate off by 38-fold (1.58 log units), on the low side; measured number above the stated range.
By their numbers in this assay, from the lowest: compound 2; then compound 3; then compound 1; then compound 4.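

In this assay, within the data shown here, the first pair to isolate this change runs against the direction the earlier compounds hinted at: amino in place of nitro, on an aromatic carbon ortho to a methoxy group and meta to a large group, gives a 17-fold higher number from compound 3 to compound 4 (1.22 log units; beyond the scatter). Among these compounds, on this core, the position is far from indifferent to the group it carries, and of the two groups compared here, nitro goes with the lower number, so the amino group on the different core of compound 2 proved no guide to this step. Nothing at hand explains why the number moves this way.

The compounds shown leave open whether nitro is unusual at this position, or whether other groups on the same aromatic carbon, such as a nitrile, a carboxylic acid or a methylamino group, would also keep the number near that of compound 3. They also leave open whether the same exchange would move the number in the same direction on the core of compound 2, so the step can be claimed only for this one pair.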